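Trimethoxyphenyl ketone on a thiophene-bearing fused core

The source may hold more compounds than are shown below. What is called first, only, known or untested is meant among the compounds shown, and "the series" means these compounds.

Measured in a functional assay on PC-3 cells (Homo sapiens) for cytotoxicity, read by MTT assay, with a stated time of 48 h; on this read-out lower numbers stand for stronger inhibition and higher numbers for weaker inhibition:
Compound 1, `COc1cc(C(=O)C2Sc3nnc(-c4cc(OC)c(OC)c(OC)c4)n3NC2c2ccco2)cc(OC)c1OC`, gives 52200 nM.
Compound 2, `COc1cc(-c2nnc3n2NC(c2ccco2)C(C(=O)c2ccc(F)cc2)S3)cc(OC)c1OC`, gives 27700 nM.
Compound 3, `COc1cc(-c2nnc3n2NC(c2cccs2)C(C(=O)c2ccc(F)cc2)S3)cc(OC)c1OC`, gives 27400 nM.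

Compound 3 differs from compound 2 only in the core, by thiophen-2-yl in place of furan-2-yl on a saturated ring carbon, and this gave a 1.0-fold lower number from compound 2 to compound 3 (0.00 log units; within the scatter). Compound 1 differs from compound 2 by 3,4,5-trimethoxyphenyl in place of 4-fluorophenyl on a carbonyl carbon, which gave a 1.9-fold higher number from compound 2 to compound 1 (0.28 log units; within the scatter).

Compound 4, `COc1cc(C(=O)C2Sc3nnc(-c4cc(OC)c(OC)c(OC)c4)n3NC2c2cccs2)cc(OC)c1OC`, is not yet measured in this assay. It differs from compound 3 by 3,4,5-trimethoxyphenyl in place of 4-fluorophenyl on a carbonyl carbon, which is the same change, at the same place, as that from compound 2 to compound 1. Among the compounds with values here, on this basis the step is expected to be a 1.8-fold higher number from compound 3 to compound 4 (0.24 log units; within the scatter), because the one earlier instance of the change gave a 1.9-fold higher number from compound 2 to compound 1 (0.28 log units; within the scatter), with the caution that a single pair is a thin basis. Compound 4 is therefore estimated at 48000 nM in this assay, with a plausible range from 20000 nM to 110000 nM.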

Compound 4, half-maximal inhibitory concentration: > 100000 nM
Compound 4: a limit, no number; the forecaster's own chance of this, stated with the estimate: 15%; middle value at least 2.0-fold (0.31 log units) away from the limit.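

In this assay compound 4 gives > 100000 nM, which is a limit of the assay and not a number. With the thiophen-2-yl group on the core, 3,4,5-trimethoxyphenyl in place of 4-fluorophenyl on a carbonyl carbon gave an at least 3.6-fold higher number from compound 3 to compound 4 (0.56 log units; beyond the scatter), so the change shows a loss there, but it does not show that the size of the step carries over from the furan-2-yl core: the same change on two cores in this assay, a 1.9-fold higher number (0.28 log units; within the scatter) from compound 2 to compound 1 and an at least 3.6-fold higher number (0.56 log units; beyond the scatter) from compound 3 to compound 4; the limit leaves it open whether they differ Read the other way, thiophen-2-yl in place of furan-2-yl gave an at least 1.9-fold higher number from compound 1 to compound 4 (0.28 log units; that floor lies within the scatter), and this floor does not show that the ring swap behaves differently with the two carbonyl groups: the same change on two cores in this assay, a 1.0-fold lower number (0.00 log units; within the scatter) from compound 2 to compound 3 and an at least 1.9-fold higher number (0.28 log units; that floor lies within the scatter) from compound 1 to compound 4; the limit leaves it open whether they differ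

The compounds shown leave open how an unsubstituted phenyl or a 4-methoxyphenyl on the carbonyl carbon would compare. They also leave open whether a single methoxy group is enough to produce the loss.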